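Amide aryl swaps and tolerated concentration across the series

A few compounds are considered here, and "the series" means these few. Any claim that something is new, unique, unknown or untested is made for them only; others in the source may bear on it.

Measured so far in an ADME assay on LLC-MK2 cells (Macaca mulatta) for cytotoxicity, read by spectrophotometry and crystal violet staining, with a stated time of 4 days; a higher number here means that more compound is tolerated, a lower number that less compound is tolerated:
compound 1 `CC(C)n1ncc2c(C(=O)Nc3cccnc3)cc(-c3cccs3)nc21`: > 200000 nM
compound 2 `CC(C)n1ncc2c(C(=O)Nc3ccncc3)cc(-c3cccs3)nc21`: 6300 nM
compound 3 `CC(C)n1ncc2c(C(=O)Nc3cccc(S(N)(=O)=O)c3)cc(-c3cccs3)nc21`: 25000 nM

The value of compound 1 is a limit of the assay, not a number (the limit of > 200000 nM in this assay, at which 1 of the 3 values shown sits). Compound 3 holds the highest of the two actual numbers; the step of a 4.0-fold higher number from compound 2 to compound 3 (0.60 log units; beyond the scatter) separates it from compound 2, and the step of an at least 8.0-fold lower number from compound 1 to compound 3 (0.90 log units; beyond the scatter) descends from compound 1. Compound 4 `CC(C)n1ncc2c(C(=O)Nc3cncnc3)cc(-c3cccs3)nc21` differs from compound 3 only at the amide nitrogen: pyrimidin-5-yl in place of 3-sulfamoylphenyl on an amide-type nitrogen. Among the compounds with values here, no measured step exchanges a 3-sulfamoylphenyl for a pyrimidin-5-yl, but both steps into compound 3 show that changing the aryl on the amide nitrogen moves this assay modestly to largely, in either direction. The entering ring is a nitrogen heteroaryl, as in compounds 1 and 2, which sit on either side of compound 3. Compound 4 is therefore expected to shift by a 2.4-fold higher number from compound 3 to compound 4 (0.38 log units; beyond the scatter), toward the higher side, with wide uncertainty. Compound 4 is estimated at 60000 nM, between 12000 nM and 250000 nM.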

Compound 4, half-maximal cytotoxic concentration: 20000 nM
Compound 4: middle estimate off by 3.0-fold (0.48 log units), on the high side, and the stated range covers the measured number.
By their numbers in this assay, from the lowest: compound 2; then compounds 4 and 3 (each within the scatter of the next). At a limit, above all of these: compound 1.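

In this assay, pyrimidin-5-yl on the amide-type nitrogen matches 3-sulfamoylphenyl, with a 1.3-fold lower number from compound 3 to compound 4 (0.10 log units; within the scatter), so the 3-sulfamoylphenyl group is not required to reach this level. Among the nitrogen heteroaryls, the identity of the ring still matters, as pyrimidin-5-yl in place of pyridin-4-yl gives a 3.2-fold higher number from compound 2 to compound 4 (0.50 log units; beyond the scatter). The value of compound 1 is a limit and not a number, so an at least 10-fold lower number from compound 1 to compound 4 (1.00 log units; beyond the scatter) is only a bound: the limit of > 200000 nM in this assay, at which 1 of the 4 values shown sits.

Open, as far as these compounds go, is how far compound 1 lies past its limit. Also open, from the compounds shown here alone, is how an aryl ring bearing an amine or a carboxylic acid would behave at this position.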